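Side-chain amide changes on a shared core

A few compounds are considered here, and "the series" means these few. Any claim that something is new, unique, unknown or untested is made for them only; others in the source may bear on it.

Three measured compounds share one core and differ only in the amide-bearing side chain on the saturated ring. Compound 1 `COc1cc2nc(N3CCC(C(=O)NCCO)CC3)nc(N)c2cc1OC` gives 1.73 nM in an assay on isolated protein for displacement of a labelled ligand from Adrenergic receptor alpha-1 (Rattus norvegicus); a lower number here means a stronger inhibitor, a higher number a weaker inhibitor. Compound 2 `CCN(CC)C(=O)C1CCN(c2nc(N)c3cc(OC)c(OC)cc3n2)CC1` gives 1.11 nM in this assay. Compound 3 `COc1cc2nc(N3CCC(CC(=O)NCC4CC4)CC3)nc(N)c2cc1OC` gives 1.08 nM in this assay. The number for compound 3 is the smallest of the three, yet a 1.6-fold lower number from compound 1 to compound 3 (0.20 log units; within the scatter) and a 1.0-fold lower number from compound 2 to compound 3 (0.01 log units; within the scatter) both remain within the scatter, so no real separation among the three can be read from them.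

Compound 4 `CCCCNC(=O)CCC1CCN(c2nc(N)c3cc(OC)c(OC)cc3n2)CC1` has not yet been measured. Its change from compound 3 is (butylcarbamoyl)methyl in place of (cyclopropylmethyl)carbamoyl on a saturated chain carbon bound to a saturated ring carbon. For the measured compounds named here, the steps that bear on this are the earlier exchanges in the same amide region: a 1.6-fold lower number from compound 1 to compound 2 (0.19 log units; within the scatter), a 1.6-fold lower number from compound 1 to compound 3 (0.20 log units; within the scatter) and a 1.0-fold lower number from compound 2 to compound 3 (0.01 log units; within the scatter), none of them beyond the scatter. A further change of this kind is therefore expected to give no step beyond the scatter in this assay, which is what the estimated 1.1-fold higher number from compound 3 to compound 4 (0.05 log units; within the scatter) means. Compound 4 is expected to give about 1.2 nM, with a range from 0.5 nM to 3 nM.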

Compound 4, inhibition constant: 0.47 nM
Beside the measured number, compound 4's estimate is 2.6-fold (0.41 log units) above it; measured number below the stated range.
By their numbers in this assay, from the lowest: compound 4; then compounds 3, 2 and 1 (each within the scatter of the next).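

In this assay, for the compounds shown here, (butylcarbamoyl)methyl in place of (cyclopropylmethyl)carbamoyl on a saturated chain carbon bound to a saturated ring carbon gives a 2.3-fold lower number from compound 3 to compound 4 (0.36 log units; beyond the scatter), which, unlike the earlier steps, lies beyond the scatter. The 2-(butylcarbamoyl)ethyl side chain also separates from the two amides set directly on the saturated ring carbon, with a 2.4-fold lower number from compound 2 to compound 4 (0.37 log units; beyond the scatter) and a 3.7-fold lower number from compound 1 to compound 4 (0.57 log units; beyond the scatter), so this part of the molecule can shift the number after all, if only modestly. Nothing available explains this shift.

The step from compound 3 to compound 4 removes the three-membered ring and adds one carbon together, so the share of each remains unresolved. As far as these compounds go, whether a longer chain on the amide nitrogen, a cyclohexyl group there, or an amine or carboxylic acid in place of the amide would hold or lower the number also remains open.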